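A few compounds are considered here, and "the series" means these few. Any claim that something is new, unique, unknown or untested is made for them only; others in the source may bear on it.

Working notes on the selenourea series.

Of the compounds shown here, two have been measured so far: compound 1 `O=C(/N=C(/NC(=O)c1cccs1)[Se]Cc1ccccc1)c1cccs1` and compound 2 `C[Se]/C(=N\C(=O)c1cnc2ccccc2c1)NC(=O)c1cnc2ccccc2c1`. In a functional assay on HT-29 cells (Homo sapiens) for cytotoxicity, read by MTT assay, with a stated time of 72 h (a lower number here means that less compound is tolerated, a higher number that more compound is tolerated), compound 1 gives > 100000 nM, which is a limit of the assay and not a number. In this assay compound 2 gives > 100000 nM, again a limit rather than a number. Going by the values given here, compound 1 and compound 2 differ in more than one place, so no single step between them can be read; their two values show only that each sits at the limit. Where compound 2 stands is therefore fixed by the limit of > 100000 nM in this assay, at which 2 of the 2 values shown sit.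

The next compound, compound 3 `O=C(/N=C(/NC(=O)c1cnc2ccccc2c1)[Se]Cc1ccccc1)c1cnc2ccccc2c1`, differs from compound 2 by phenyl in place of hydrogen on a saturated chain carbon bound to a selenium atom. Compound 1 already carries the benzyl on selenium and sits at the limit, so no movement beyond the scatter is anticipated for this step. In this assay the expected step from compound 2 to compound 3 is a number no higher from compound 2 to compound 3 (the limit leaves the size open), which is no change beyond the scatter. Compound 3 is accordingly expected to give about 100000 nM, with a range from 40000 nM to 200000 nM, most likely again reported only as a limit.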

Compound 3, concentration lethal to 50% of the cells: > 100000 nM
Compound 3 was reported as a limit (the forecaster's own chance of this, stated with the estimate: 70%); the middle value lies on the limit itself.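

Going by these compounds alone, no step from compound 2 to compound 3 can be read, as both values are limits of the assay and not numbers. What the compounds shown leave open is how the true values of compound 1, compound 2 and compound 3 compare in this assay, all resting on one limit: the limit of > 100000 nM in this assay, at which 3 of the 3 values shown sit.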